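Trimethoxyphenyl for Hydroxyphenyl: An Expected Growth-Inhibition Value

The compounds below may be only part of what the source reports. "The series", "measured", "known", "first", "only" and "open" are said of these compounds alone.

Compound 1 `Cc1cc(O)c(C2=NN(c3ccc(S(N)(=O)=O)cc3)C(c3ccccc3O)C2)cc1Cl`: 22500 nM
Compound 2 `COc1ccc(C2CC(c3cc(Cl)c(C)cc3O)=NN2c2ccc(S(N)(=O)=O)cc2)cc1OC`: 34300 nM

Both numbers come from a functional assay on Hs-578T cells (Homo sapiens) for antiproliferative activity, with a stated time of 48 h; on this read-out higher numbers stand for weaker inhibition of growth and lower numbers for stronger inhibition of growth. Compound 1 gives the smaller of the two numbers, yet the gap a 1.5-fold higher number from compound 1 to compound 2 (0.18 log units; within the scatter) lies within the scatter, so the two cannot be ranked. Compound 3 `COc1ccc(C2CC(c3cc(Cl)c(C)cc3O)=NN2c2ccc(S(N)(=O)=O)cc2)c(OC)c1OC` differs from compound 1 in one place: 2,3,4-trimethoxyphenyl in place of 2-hydroxyphenyl on a saturated ring carbon. Among the compounds with values here, the only measured step that bears on this change is a 1.5-fold higher number from compound 1 to compound 2 (0.18 log units; within the scatter), where a methoxy-bearing phenyl likewise replaced the 2-hydroxyphenyl on the same saturated ring carbon and the number barely moved. A step of a 1.3-fold higher number from compound 1 to compound 3 (0.12 log units; within the scatter) is therefore expected, nothing beyond the scatter. Compound 3 is estimated at 30000 nM, expected between 12000 nM and 75000 nM.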

Compound 3, concentration for total growth inhibition: 7020 nM
Compound 3: middle estimate off by 4.3-fold (0.63 log units), on the high side, and the stated range ends above it.
By their numbers in this assay, from the lowest: compound 3; then compounds 1 and 2 (each within the scatter of the next).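

Replacing the 2-hydroxyphenyl on this saturated ring carbon with 2,3,4-trimethoxyphenyl does change the read-out: there is a 3.2-fold lower number from compound 1 to compound 3 (0.51 log units; beyond the scatter) and thus stronger inhibition of growth. Losing the 2-hydroxyphenyl is not enough by itself, since compound 2 also lacks it and stays within the scatter of compound 1, while one added methoxy gives a 4.9-fold lower number from compound 2 to compound 3 (0.69 log units; beyond the scatter) in the same assay. The compounds shown leave open whether another group on this phenyl ring, such as ethoxy or an amine, would serve as well as methoxy. No measurement available here explains the lower number of compound 3.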